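The source may report more compounds than this note shows. Statements on the series, on what has been measured and on what is new or still open speak of the compounds shown alone.

Working notes on the series.

In a functional assay on the whole organism with Rattus norvegicus as the target (on this read-out higher numbers stand for weaker inhibition and lower numbers for stronger inhibition), compound 1 `Cc1ccc(O)c(NCCCN2CCN(C(c3ccc(F)cc3)c3ccc(F)cc3)CC2)c1` gives 0.1 ug/mL. Compound 2 `Cc1ccc(O)c(N(CCCN2CCN(C(c3ccc(F)cc3)c3ccc(F)cc3)CC2)C(C)C)c1` carries the change isopropyl in place of hydrogen on a nitrogen on an aromatic ring on the same core, and in this assay compound 2 gives 1.2 ug/mL. The step is a 12-fold higher number from compound 1 to compound 2 (1.08 log units; beyond the scatter), so the isopropyl on the nitrogen clearly costs potency here.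

Compound 3 `Cc1ccc(O)c(NCCCN2CCC(C(O)(c3ccccc3)c3ccc(Cl)cc3)CC2)c1` is built on a different core; the difference between the two cores is not broken down here. In this assay compound 3 gives 0.041 ug/mL, the lowest number of the three measured compounds, with compound 1 nearest to it and compound 2 furthest from it.

Compound 4 `Cc1ccc(O)c(N(CCCN2CCC(C(O)(c3ccccc3)c3ccc(Cl)cc3)CC2)C(C)C)c1` has not yet been measured. It stands to compound 3 as compound 2 stands to compound 1: the change is isopropyl in place of hydrogen on a nitrogen on an aromatic ring, and the surroundings of the nitrogen read the same in both cases, so this is taken as the same change on a new core. For the measured compounds named here, only one measured example of the change exists, so the expectation rests on a single step. Compound 4 is expected to lose potency against compound 3 by about the same amount, with the expected step of an 11-fold higher number from compound 3 to compound 4 (1.04 log units; beyond the scatter), because the change already gave a 12-fold higher number from compound 1 to compound 2 (1.08 log units; beyond the scatter). The estimate for compound 4 in this assay is 0.45 ug/mL, with a range of 0.15 ug/mL to 1.3 ug/mL allowing for the core being different and for the usual scatter.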

Compound 4, half-maximal inhibitory concentration: 1 ug/mL
The estimate for compound 4 lay 2.2-fold (0.35 log units) below the measured number; the measured number falls inside the stated range.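

In this assay, isopropyl in place of hydrogen on the nitrogen on the aromatic ring gives a 24-fold higher number from compound 3 to compound 4 (1.39 log units; beyond the scatter), so the loss of potency seen on the core of compound 1 also appears on the core of compound 3. Set side by side, the two steps show no difference in size that can be separated from the scatter: the same change on two cores in this assay, a 12-fold higher number (1.08 log units; beyond the scatter) from compound 1 to compound 2 and a 24-fold higher number (1.39 log units; beyond the scatter) from compound 3 to compound 4, 2.0-fold (0.31 log units) apart, within the scatter of two such steps. For the compounds shown here, this supports treating the change as carrying over between these two cores in this assay, but it rests on only two matched pairs, does not show that the larger number for the second pair is a real core effect, does not extend to any other core, and does not explain why the isopropyl costs potency.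

The compounds shown leave open how the loss depends on the group on this nitrogen, since only hydrogen and isopropyl appear there, and a methyl or an ethyl group could show whether a smaller group keeps more of the potency of compound 1 and compound 3. Also open, from the compounds shown here alone, is whether an acetyl group on the same nitrogen, or a longer chain in place of the isopropyl, would give a step of similar size on both cores.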